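Fluoro for Methyl Across Two Related Cores

A few compounds are considered here, and "the series" means these few. Any claim that something is new, unique, unknown or untested is made for them only; others in the source may bear on it.

Compound 1 `Cc1ccc(-c2nnc(COc3ccc(C#N)c(F)c3)o2)cc1`: > 50000 nM, a limit of the assay
Compound 2 `N#Cc1ccc(OCc2nnc(-c3ccc(F)cc3)o2)cc1F`: 20500 nM
Compound 3 `Cc1ccc(-c2nnc(COc3ccc(-c4nnco4)cc3)o2)cc1`: > 50000 nM, a limit of the assay

In a functional assay on MCF7 cells (Homo sapiens) for cytotoxicity, read by MTT assay, with a stated time of 48 h (a lower number here means a stronger inhibitor, a higher number a weaker inhibitor), compound 1 reaches only a limit of the assay, > 50000 nM. Compound 2 gives a measured number, 20500 nM. The two differ by a single change, (fluoro in place of methyl on an aromatic carbon), and that change produces an at least 2.4-fold lower number from compound 1 to compound 2 (0.38 log units; beyond the scatter). Compound 3 also stops at a limit of the assay, > 50000 nM. The difference between the core of compound 3 and the core of compound 1 is not broken down here.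

Compound 4 `Fc1ccc(-c2nnc(COc3ccc(-c4nnco4)cc3)o2)cc1` has not yet been measured in this assay. It relates to compound 3 exactly as compound 2 relates to compound 1: the change is fluoro in place of methyl on an aromatic carbon, with the same place in both pairs, so it is the same change. Two of the three values shown sit at the limit of > 50000 nM in this assay, at which 2 of the 3 values shown sit, and compound 3 is one of them, so the starting point for compound 4 is itself undefined. Resting on the step of an at least 2.4-fold lower number from compound 1 to compound 2 (0.38 log units; beyond the scatter) seen from compound 1, compound 4 is expected to move by about an at least 2.0-fold lower number from compound 3 to compound 4 (0.30 log units; that floor lies within the scatter). The estimate for compound 4 is therefore 25000 nM, expected between 8000 nM and 60000 nM.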

Compound 4, half-maximal inhibitory concentration: 35600 nM
Compound 4: the middle estimate sits 1.4-fold (0.15 log units) below what was measured, within the range that was stated.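

In this assay, replacing 4-methylphenyl with 4-fluorophenyl on the core of compound 3 gives an at least 1.4-fold lower number from compound 3 to compound 4 (0.14 log units; that floor lies within the scatter). This shows that the change points the same way on both cores, toward a lower number, and that it carries over at least in direction, but the two steps cannot be told apart in size: the same change on two cores in this assay, an at least 2.4-fold lower number (0.38 log units; beyond the scatter) from compound 1 to compound 2 and an at least 1.4-fold lower number (0.14 log units; that floor lies within the scatter) from compound 3 to compound 4; the limit leaves it open whether they differ. It does not show that the change is worth a fixed amount from one core to another, since compound 1 and compound 3 each stand only at a limit of the assay and neither step has a true size: the limit of > 50000 nM in this assay, at which 2 of the 4 values shown sit.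

The compounds shown leave open whether a chloro group or a methoxy group in that same place would also go with a lower number on both cores. They also leave open how an amine or a carboxylic acid in place of the nitrile on the core of compound 2 would read in this assay.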